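The source may report more compounds than this note shows. Statements on the series, on what has been measured and on what is new or still open speak of the compounds shown alone.

Three related compounds anchor this small series in a functional assay on OCI-Ly3 cells (Homo sapiens) for inhibition, read by CellTiter-Glo, with stated times of 48 h and 96 h; a higher number here means a weaker inhibitor of growth, a lower number a stronger inhibitor of growth. For compound 1 (`CC(C)[C@H](NC(=O)OCc1ccccc1)C(=O)N1CCC[C@H]1C(=O)N(C)[C@@H](CCCNC(=N)N)C(=O)CF`) the entry reads "not determined" (no result reported), so it offers no number for comparison. Compound 2 (`CC(C)[C@H](NC(=O)c1ccccc1Br)C(=O)N1CCC[C@H]1C(=O)N[C@@H](CCCNC(=N)N)C(=O)CF`) gives 4240 nM. Compound 3 (`CC[C@H](C)[C@H](NC(=O)OCc1ccccc1)C(=O)N1CCC[C@H]1C(=O)N[C@@H](CCCNC(=N)N)C(=O)CF`) gives 2440 nM, which lies within the usual scatter of the value for compound 2, so the data do not separate the two. They also differ in more than one place, so their values cannot be tied to any single structural change.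

Compound 4 (`N=C(N)NCCC[C@H](NC(=O)[C@@H]1CCCN1C(=O)[C@@H](NC(=O)OCc1ccccc1)C1CCCCC1)C(=O)CF`) has not yet been measured. It differs from compound 3 in one place: cyclohexyl in place of sec-butyl on a saturated chain carbon bound to an amide-type nitrogen and a carbonyl carbon. In plain terms, cyclohexyl stands in place of sec-butyl on a saturated chain carbon bound to an amide-type nitrogen and a carbonyl carbon.

For the measured compounds named here, no measured pair in this set isolates a change of this kind, so there is no direct guide to its effect. The starting point is therefore compound 3 at 2440 nM, and no step beyond the scatter is expected in this assay, with neither direction favoured. The estimated change is a 1.0-fold lower number from compound 3 to compound 4 (0.01 log units; within the scatter). Compound 4 is expected at about 2400 nM, with an estimated range of 800 nM to 7000 nM.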

Compound 4, concentration for 50% growth inhibition: 1450 nM
Compound 4: the middle estimate sits 1.7-fold (0.22 log units) above what was measured, within the range that was stated.
By their numbers in this assay, from the lowest: compounds 4, 3 and 2 (each within the scatter of the next, the first and the last beyond it).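

In this assay, for the compounds shown here, the first change in one place that can be read is a 1.7-fold lower number from compound 3 to compound 4 (0.23 log units; within the scatter). Going by these compounds alone, this shows that on a saturated chain carbon bound to an amide-type nitrogen and a carbonyl carbon, an open sec-butyl group can give way to a cyclohexyl ring with no step that this assay can separate from ordinary repeat variation, so adding a ring of carbon here does not visibly cost growth inhibition in these cells. Nothing measured here accounts for this result, and it gives no basis for a reason behind it.

The two groups that can be compared at this position, sec-butyl and cyclohexyl, are both made only of carbon and hold no hydrogen-bond donors or acceptors, so a single step says little about groups of a different kind. Going by these compounds, it remains open whether a flat phenyl ring, a compact tert-butyl group, or a chain ending in an amine or a carboxylic acid would leave the number unchanged or move it clearly beyond the scatter in either direction.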